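Compound 3 to compound 4: a changed aromatic group

The source may hold more compounds than are shown below. What is called first, only, known or untested is meant among the compounds shown, and "the series" means these compounds.

Measured in a functional assay on SGC-7901 cells (Homo sapiens) for antiproliferative activity, read by MTT assay, with a stated time of 72 h (a higher number here means a weaker inhibitor, a lower number a stronger inhibitor), as follows:
- compound 1 `CCOc1ccc(-c2ccc3ncn(-c4cc(OC)c(OC)c(OC)c4)c3c2)cc1` gives 2970 nM as its value
- compound 2 `COc1cc(-n2cnc3ccc(-c4ccccc4Cl)cc32)cc(OC)c1OC` gives > 10000 nM as a limit of the assay
- compound 3 `COc1cc(-n2cnc3ccc(-c4ccc(C(F)(F)F)cc4)cc32)cc(OC)c1OC` gives 890 nM as its value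

Compound 3 is the strongest of the three, with a 3.3-fold lower number from compound 1 to compound 3 (0.52 log units; beyond the scatter) and with an at least 11-fold lower number from compound 2 to compound 3 (1.05 log units; beyond the scatter) in the same direction. Compound 4 `COc1cc(-n2cnc3ccc(-c4cccc(C)c4C)cc32)cc(OC)c1OC` is still unmeasured. It takes 2,3-dimethylphenyl in place of 4-(trifluoromethyl)phenyl on an aromatic carbon of the shared core.

The entering group reads closer to the 2-chlorophenyl of compound 2 than to the group it replaces. The step that bears most is therefore an at least 11-fold lower number from compound 2 to compound 3 (1.05 log units; beyond the scatter) and, more weakly, an at least 3.3-fold higher number from compound 1 to compound 2 (0.52 log units; beyond the scatter) on the same carbon. Only part of the large step is expected to return, as the two groups are not the same. A higher number is expected in this assay with a 4.5-fold higher number from compound 3 to compound 4 (0.65 log units; beyond the scatter) as the estimated step. For compound 4 the estimate is 4000 nM with an expected range from 1200 nM to 12000 nM in this estimate.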

Compound 4, half-maximal inhibitory concentration: 3040 nM
For compound 4 the middle estimate is 1.3-fold (0.12 log units) above the measured one; the range from low to high includes it.
By their numbers in this assay, from the lowest: compound 3; then compounds 1 and 4 (each within the scatter of the next). At a limit, above all of these: compound 2.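

In this assay, 2,3-dimethylphenyl in place of 4-(trifluoromethyl)phenyl gives a 3.4-fold higher number from compound 3 to compound 4 (0.53 log units; beyond the scatter), so among the groups shown on this aromatic carbon, the 4-(trifluoromethyl)phenyl of compound 3 keeps the lowest number. The new group also gives an at least 3.2-fold lower number from compound 2 to compound 4 (0.51 log units; beyond the scatter), while 4-ethoxyphenyl and 2,3-dimethylphenyl cannot be told apart, with a 1.0-fold higher number from compound 1 to compound 4 (0.01 log units; within the scatter). The entry for compound 2 is a limit of the assay and not a number: the limit of > 10000 nM in this assay, at which 1 of the 4 values shown sits.

Compound 3 and compound 4 differ both in the substituents on the phenyl and in where those substituents sit, so the two contributions remain unseparated. Going by these compounds, how a 4-methylphenyl or a 4-aminophenyl would stand on this carbon remains open.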